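Swapping Benzyloxy for 4-Methoxyphenyl: An Expected Small Step

The source may hold more compounds than are shown below. What is called first, only, known or untested is meant among the compounds shown, and "the series" means these compounds.

In a functional assay on DLD-1 cells (Homo sapiens) for antiproliferative activity, read by CellTiter-Glo, with a stated time of 72 h (a higher number here means a weaker inhibitor, a lower number a stronger inhibitor), compound 1 `CC1CCN(C2CCN(S(=O)(=O)c3ccc(C#N)cc3)CC2)CC1` gives 2800 nM, and compound 2 `CC1CCN(C2CCN(S(=O)(=O)c3ccc(OCc4ccccc4)cc3)CC2)CC1` gives 385 nM, the lower of the two numbers available. Compound 3 `Cc1cc(C)c(S(=O)(=O)N2CCC(C(=O)N3CCC(C)CC3)CC2)c(C)c1` is recorded only as a limit, > 5000 nM.

Attention now turns to compound 4 `COc1ccc(-c2ccc(S(=O)(=O)N3CCC(N4CCC(C)CC4)CC3)cc2)cc1`, which has the same atoms as compound 2, joined differently: 4-methoxyphenyl in place of benzyloxy on an aromatic carbon. Here 4-methoxyphenyl stands in place of benzyloxy on an aromatic carbon of a six-membered aromatic ring of carbon only, para to a large group.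

For the measured compounds named here, only one measured step bears on this change. With benzyloxy in place of cyano at the same place, the data show a 7.3-fold lower number from compound 1 to compound 2 (0.86 log units; beyond the scatter). That step, however, replaced a different group and says nothing directly about exchanging benzyloxy for 4-methoxyphenyl. The two groups match in every feature counted, so a much smaller step than that one is expected in this assay. It may stay within the scatter, with at most a slight, uncertain drift toward a higher number.

The estimate amounts to an expected 1.3-fold higher number from compound 2 to compound 4 (0.11 log units; within the scatter). For compound 4, the expected value is 500 nM, with an estimated range from 130 nM to 2000 nM.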

Compound 4, half-maximal inhibitory concentration: 263 nM
Compound 4: middle estimate off by 1.9-fold (0.28 log units), on the high side, and the stated range covers the measured number.
By their numbers in this assay, from the lowest: compounds 4 and 2 (each within the scatter of the next); then compound 1. At a limit, above all of these: compound 3.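

In this assay the exchange of benzyloxy for 4-methoxyphenyl on this aromatic carbon gives a 1.5-fold lower number from compound 2 to compound 4 (0.17 log units; within the scatter), so at this place the two groups, which have the same atoms joined differently, cannot be told apart in this read-out. The earlier compounds shown here tied the lower number to benzyloxy alone, whereas the second group also stands clear of cyano, with an 11-fold lower number from compound 1 to compound 4 (1.03 log units; beyond the scatter), which shows that the drop from the cyano compound does not depend on benzyloxy itself. Nothing in the data shown accounts for why the two groups read alike.

The compounds shown leave open whether a group without a six-membered aromatic ring, such as a plain methoxy or a longer alkyl chain, would hold the number at this level on the same carbon. They also leave open whether the methoxy of 4-methoxyphenyl contributes anything, a question that a bare phenyl, or a phenyl carrying an amine or a carboxylic acid instead, would help to settle.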